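The source may report more compounds than this note shows. Statements on the series, on what has been measured and on what is new or still open speak of the compounds shown alone.

Compound 1 `O=C(Nc1ccc(NCc2ccc(Cl)cc2)cc1Cl)c1cc(Cl)ccc1O` and compound 2 `O=C(Nc1ccc(NCc2cccc(C(F)(F)F)c2)cc1Cl)c1cc(Cl)ccc1O` share one core and differ only in the aryl ring on the saturated chain carbon bound to the ring nitrogen. Among the compounds with values here, in an ADME assay on A549 cells (Homo sapiens) for cytotoxicity, read by resazurin assay, with a stated time of 48 h (on this read-out lower numbers stand for higher toxicity in this test and higher numbers for lower toxicity in this test), compound 1 gives 59700 nM, the highest of the two numbers known, while compound 2 gives 13300 nM; the change from compound 1 to compound 2 a 4.5-fold lower number from compound 1 to compound 2 (0.65 log units; beyond the scatter) is the single step recorded so far.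

Compound 3 `CC(CCO)Nc1ccc(NC(=O)c2cc(Cl)ccc2O)c(Cl)c1` has not yet been measured. It differs from compound 1 as follows: 3-hydroxy-1-methylpropyl in place of 4-chlorobenzyl on a nitrogen on an aromatic ring. Within the data shown here, the one known step exchanges one aryl ring for another and so bears only loosely on this change, in which the ring leaves altogether and a short open chain with a hydroxyl enters. Among the measured compounds shown here, with no closer precedent, the expectation for this assay is a small shift towards a higher number, that is towards lower toxicity, or no step beyond the scatter, so that the estimated step from compound 1 to compound 3 is a 1.4-fold higher number from compound 1 to compound 3 (0.15 log units; within the scatter). Compound 3 is therefore estimated at 85000 nM, with a plausible range from 30000 nM to 250000 nM.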

Compound 3, half-maximal cytotoxic concentration: 200000 nM
Beside the measured number, compound 3's estimate is 2.4-fold (0.37 log units) below it; the range from low to high includes it.
By their numbers in this assay, from the lowest: compound 2; then compound 1; then compound 3.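

In this assay, the earlier step at this position exchanged one aryl ring for another and moved to a lower number, whereas removing the ring altogether and introducing an open chain moves the read-out the other way, a 3.4-fold higher number from compound 1 to compound 3 (0.53 log units; beyond the scatter). Together with the step of a 4.5-fold lower number from compound 1 to compound 2 (0.65 log units; beyond the scatter), this shows that the group on a nitrogen on an aromatic ring can shift the number in either direction from compound 1, and that the shared core does not need the aryl ring for a reading to be obtained in this test. No accompanying evidence bears on this result, so the shift can be recorded but not explained.

Compound 3 loses the ring and gains the hydroxyl in a single change, so the compounds shown leave open which of the two accompanies the higher number, a question that a 1-methylpropyl group without the hydroxyl would address. They also leave open how the number would respond to a longer chain, or to an amine or a carboxylic acid at the end of the chain in place of the hydroxyl.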